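The compounds below may be only part of what the source reports. "The series", "measured", "known", "first", "only" and "open" are said of these compounds alone.

Compound 1 `C[C@H](CSc1nonc1/C(=N/O)Nc1ccc(F)c(Br)c1)NC(=O)CS(N)(=O)=O` carries a single stereocentre in its chain. In an assay for inhibition of Indoleamine 2,3-dioxygenase 1 (Homo sapiens), read by fluorescence, with a stated time of 1 h (on this read-out higher numbers stand for weaker inhibition and lower numbers for stronger inhibition), compound 1 gives 110 nM, the higher of the two numbers recorded; compound 2 `O=C(NCCSc1nonc1/C(=N/O)Nc1ccc(F)c(C(F)F)c1)C1CS(=O)(=O)C1` gives 70 nM in this assay, a gap within the scatter, so no order can be read between them. Compound 3 `C[C@@H](CSc1nonc1/C(=N/O)Nc1ccc(F)c(Br)c1)NC(=O)CS(N)(=O)=O` is related to compound 1 as follows: the two compounds have the same atoms and bonds and differ only in configuration as drawn: 1 of 2 stereo elements differ; a stereocentre at a saturated chain carbon is drawn R in compound 1 and S in compound 3. Going by the values given here, no measured pair here isolates such a change of configuration, so its size is unknown; a modest shift toward weaker inhibition is expected, a 1.8-fold higher number from compound 1 to compound 3 (0.26 log units; within the scatter), though either direction would be unsurprising. Compound 3 is therefore estimated at 200 nM, within 60 nM to 1000 nM.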

Compound 3, half-maximal inhibitory concentration: 93 nM
Compound 3: the middle estimate sits 2.2-fold (0.33 log units) above what was measured; the measured number falls inside the stated range.
By their numbers in this assay, from the lowest: compounds 2, 3 and 1 (each within the scatter of the next).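

Going by these compounds alone, this pair is the first to isolate the stereocentre at the saturated chain carbon, so the step can be attributed to that one place: the fact that compounds 1 and 3 differ only in the configuration as drawn. In this assay, redrawing that centre from R to S gives a 1.2-fold lower number from compound 1 to compound 3 (0.07 log units; within the scatter), so this assay does not tell the two configurations apart in this series. The earlier compounds shown here could not show this, as they offered no such pair. From the compounds shown here alone, whether the configuration would still make so little difference with an ethyl group or a carboxylic acid at that stereocentre stays open.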